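The source may hold more compounds than are shown below. What is called first, only, known or untested is meant among the compounds shown, and "the series" means these compounds.

Compound 1 `CCCCCc1ccc(NS(=O)(=O)c2ccc(N3CCNC3=O)cc2)cc1` carries a pentyl chain on its aniline ring and, in a functional assay on M21 cells (Homo sapiens) for antiproliferative activity, read by sulforhodamine B assay, with a stated time of 48 h (a higher number here means a weaker inhibitor, a lower number a stronger inhibitor), compound 1 gives 870 nM, the higher of the two numbers measured here. For the measured compounds named here, its only measured neighbour, compound 2 `O=C1NCCN1c1ccc(S(=O)(=O)Nc2ccc3c(c2)CCC3)cc1`, gives 130 nM in this assay, a gap beyond the usual scatter. Compound 3 `CCCCc1ccc(NS(=O)(=O)c2ccc(N3CCNC3=O)cc2)cc1` is compound 1 with one change: hydrogen in place of methyl on a saturated chain carbon, four bonds along the chain from an aromatic carbon. Going by the values given here, no measured pair shows this change, so its effect is unknown; a step from compound 1 to compound 3 of a 1.1-fold higher number from compound 1 to compound 3 (0.06 log units; within the scatter) is expected, likely within the scatter in either direction. Compound 3 is estimated at 1000 nM, between 400 nM and 2500 nM.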

Compound 3, half-maximal inhibitory concentration: 450 nM
Compound 3: the middle estimate sits 2.2-fold (0.35 log units) above what was measured, and the stated range covers the measured number.
By their numbers in this assay, from the lowest: compound 2; then compounds 3 and 1 (each within the scatter of the next).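

Replacing the methyl on the pentyl chain with hydrogen gives, in this assay, a 1.9-fold lower number from compound 1 to compound 3 (0.29 log units; within the scatter). At this position, four bonds along the chain from an aromatic carbon, the removal of one methyl therefore produces no change that can be told from the scatter. No available evidence bears on this result. Still open, from the compounds shown here alone, is whether a longer chain such as hexyl, or a shorter one such as propyl or ethyl, would stay within the scatter of compound 3. Going by these compounds, the effect of an amine or a hydroxyl on this chain also remains unknown.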